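The source may hold more compounds than are shown below. What is called first, only, known or untested is meant among the compounds shown, and "the series" means these compounds.

Compound 1 `O=C(NCc1ccc(Cl)nc1)Nc1ccc(S(=O)(=O)c2ccccc2)cc1`: 6 mL/min/kg
Compound 2 `O=C(NCc1cnccn1)Nc1ccc(S(=O)(=O)c2ccccc2)cc1`: 5 mL/min/kg

Both values come from an ADME assay on microsomes from liver (Homo sapiens) for pharmacokinetics, read by LC-MS, with a stated time of 60 min, tested at 1 uM; on this read-out lower numbers stand for slow clearance and higher numbers for fast clearance. Among the compounds with values here, compound 2 stands level with the only other measured compound: a 1.2-fold lower number from compound 1 to compound 2 (0.08 log units; within the scatter). Compound 3 `Nc1ncc(CNC(=O)Nc2ccc(S(=O)(=O)c3ccccc3)cc2)cn1` keeps the shared core and has 2-aminopyrimidin-5-yl in place of pyrazin-2-yl on a saturated chain carbon bound to an amide-type nitrogen. The one measured step at this place, given above, is the only guide and lies within the scatter, so no change beyond the scatter is expected. The expected step is a 1.2-fold higher number from compound 2 to compound 3 (0.08 log units; within the scatter). The estimate for compound 3 is 6 mL/min/kg, with an expected range of 3 mL/min/kg to 12 mL/min/kg.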

Compound 3, clearance: 3 mL/min/kg
Estimate against measurement, compound 3: 2.0-fold (0.30 log units) above, within the range that was stated.
By their numbers in this assay, from the lowest: compounds 3, 2 and 1 (each within the scatter of the next).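

In this assay the swap to 2-aminopyrimidin-5-yl, which brings a hydrogen-bond donor that pyrazin-2-yl lacks, gives a 1.7-fold lower number from compound 2 to compound 3 (0.22 log units; within the scatter) and, set against 6-chloropyridin-3-yl, gives a 2.0-fold lower number from compound 1 to compound 3 (0.30 log units; within the scatter) as well. This place, on a saturated chain carbon bound to an amide-type nitrogen, has now taken three different groups, one of them with a donor, without a change beyond the scatter. Nothing available explains why the numbers stay so close. Still open, going by these compounds, is whether a carboxylic acid, a simple amine or a longer chain at this place would move clearance beyond the scatter.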